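Methoxy in Place of Fluoro on a Shared Core

A few compounds are considered here, and "the series" means these few. Any claim that something is new, unique, unknown or untested is made for them only; others in the source may bear on it.

Of the compounds shown here, two have been tested in a functional assay on the whole organism (strain Sprague-Dawley) for inhibition, with Rattus norvegicus as the target (a lower number here means that less compound is needed, a higher number that more compound is needed for the effect), and compound 1 `O=C(O)c1cnc2c(F)cccc2c1` is the only one with a number: in this assay compound 1 shows a minimum effective dose of 150 mg/kg. Compound 2 `CCc1ccc2c(=O)c(-c3nn[nH]n3)c[nH]c2c1` is built differently, and in this assay compound 2 reaches only a limit of the assay, > 10 mg/kg; this is the limit of > 10 mg/kg in this assay, at which 1 of the 2 values shown sits, so it offers no number to set against compound 1. The unmeasured compound 3 `COc1cccc2cc(C(=O)O)cnc12` keeps the core of compound 1 and differs in one place: methoxy in place of fluoro on an aromatic carbon. Among the measured compounds shown here, no measured pair shows what this swap does here, so the step in this assay is expected to be no change at the digits printed from compound 1 to compound 3 (within the scatter), with no direction beyond the usual scatter. On that basis compound 3 is estimated to give 150 mg/kg in this assay, within a range from 50 mg/kg to 450 mg/kg.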

Compound 3, minimum effective dose: 150 mg/kg
Estimate against measurement, compound 3: no gap at the digits printed; measured number inside the range.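

Putting methoxy in place of fluoro on this aromatic carbon of the shared core gives no change at the digits printed from compound 1 to compound 3 (within the scatter) in this assay. Among the compounds shown here, this is the first pair in the set that differs in one place, and it shows that the minimum effective dose holds when the 1 heavy atom of fluoro gives way to the 2 heavy atoms of methoxy, which also bring 1 hydrogen-bond acceptor. Nothing shown here gives a reason for this result.

On these data alone, whether the dose would hold with an amine, a longer chain such as butoxy, or a plain hydrogen on this carbon remains open. A single pair also says nothing about how changes elsewhere on the shared core would behave, so no rule for the whole series follows from it.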